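The source may hold more compounds than are shown below. What is called first, only, known or untested is meant among the compounds shown, and "the series" means these compounds.

In an ADME assay on MT4 cells (Homo sapiens) for cytotoxicity, read by MTT assay (on this read-out higher numbers stand for lower toxicity in this test and lower numbers for higher toxicity in this test), compound 1 (`Cc1cc(C)cc(S(=O)(=O)c2c(C(=O)NCc3ccc(Cl)cc3)[nH]c3ccc(Cl)cc23)c1`) reads > 51200 nM as a limit of the assay and not a number. For the measured compounds named here, compound 2 (`Cc1cc(C)cc(S(=O)(=O)c2c(C(=O)NCc3ccc(N)cc3)[nH]c3ccc(Cl)cc23)c1`) gives 6370 nM as the only number so far. Compound 3 (`Cc1cc(C)cc(S(=O)(=O)c2c(C(=O)NCc3ccc(N(C)C)cc3)[nH]c3ccc(Cl)cc23)c1`) carries dimethylamino in place of amino on an aromatic carbon, para to a large group (dimethylamino in place of amino on an aromatic carbon). Going by the values given here, the sole measured step, an at least 8.0-fold lower number from compound 1 to compound 2 (0.90 log units; beyond the scatter) for amino in place of chloro, lies beyond the scatter but concerns a different exchange, so it sets no size for this one. The expected outcome is a 1.3-fold higher number from compound 2 to compound 3 (0.10 log units; within the scatter) and no step beyond the scatter in this assay as the working assumption. Compound 3 is estimated at 8000 nM with an expected range from 2500 nM to 30000 nM for now.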

Compound 3, half-maximal cytotoxic concentration: 40700 nM
For compound 3 the middle estimate is 5.1-fold (0.71 log units) below the measured one; measured number above the stated range.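

In this assay the exchange of amino for dimethylamino on this aromatic carbon, para to a large group, is not silent: a 6.4-fold higher number from compound 2 to compound 3 (0.81 log units; beyond the scatter) shows that a nitrogen at this place does not by itself bring the low number of compound 2. Against chloro, an at least 1.2-fold lower number from compound 1 to compound 3 (0.09 log units; that floor lies within the scatter) gives only a floor within the scatter, so the true distance stays unknown. Compound 1 stands at a limit of the assay and not a number: the limit of > 51200 nM in this assay, at which 1 of the 3 values shown sits.

From the compounds shown here alone, whether the low number belongs to the free amino alone stays open. Methylamino or acetamido on the same carbon would help to place it.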